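Adding a methyl: compound 2 to compound 4

The compounds below may be only part of what the source reports. "The series", "measured", "known", "first", "only" and "open" are said of these compounds alone.

- compound 1 `Cc1ccc2c(O)c(C#N)c(=O)oc2c1`: 52.4 umol/kg
- compound 2 `Cc1cccc2c(O)c(C#N)c(=O)oc12`: 32.8 umol/kg
- compound 3 `CCc1ccc2c(O)c(C#N)c(=O)oc2c1`: 23.8 umol/kg

All three values come from a functional assay on the whole organism (strain Wistar) for inhibition, with Rattus norvegicus as the target; on this read-out higher numbers stand for an effect only at larger amounts of compound and lower numbers for an effect already at smaller amounts. Compound 2 lies within the usual scatter of both compound 1 and compound 3, so its value cannot be ranked against either of them.

Compound 4 `Cc1ccc2c(O)c(C#N)c(=O)oc2c1C` differs from compound 2 by one change: methyl in place of hydrogen on an aromatic carbon. A methyl replaces hydrogen on an aromatic carbon, ortho to a methyl group. Within the data shown here, only one measured step bears on this, and only loosely: a 2.2-fold lower number from compound 1 to compound 3 (0.34 log units; beyond the scatter). That step also adds a methyl, but on a saturated chain carbon rather than an aromatic carbon, so it is a weak guide.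

In this assay, a small move to a lower number is therefore expected, no larger than that modest step and possibly within the scatter. For this change the expected step is a 1.3-fold lower number from compound 2 to compound 4 (0.12 log units; within the scatter). Compound 4 is estimated at 25 umol/kg, with an expected range of 11 umol/kg to 55 umol/kg.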

Compound 4, dose for half-maximal effect: 26.2 umol/kg
The estimate for compound 4 lay 1.0-fold (0.02 log units) below the measured number, and the stated range covers the measured number.
By their numbers in this assay, from the lowest: compounds 3, 4, 2 and 1 (each within the scatter of the next, the first and the last beyond it).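

In this assay a methyl in place of hydrogen on this aromatic carbon, ortho to a methyl group, gives a 1.3-fold lower number from compound 2 to compound 4 (0.10 log units; within the scatter), so this change has no readable effect on the number. Among these compounds, the same kind of change reached from the other parent gives a 2.0-fold lower number from compound 1 to compound 4 (0.30 log units; within the scatter), so neither of the two routes to compound 4 gives a step beyond the scatter, whereas the chain step remains the only one-place step beyond it, at a 2.2-fold lower number from compound 1 to compound 3 (0.34 log units; beyond the scatter). No supporting evidence bears on these steps.

The compounds shown leave open whether a group other than methyl on this aromatic carbon, such as an amine, a carboxylic acid or a longer chain, would move the number beyond the scatter. They also leave open whether a methyl here would give the same result without the neighbouring methyl group in place.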